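Methoxy in place of chloro: expectation for compound 4

The compounds below may be only part of what the source reports. "The series", "measured", "known", "first", "only" and "open" are said of these compounds alone.

Compound 3 `CCOC(=O)/C(=C\c1ccc(B(O)O)cc1)C(=O)c1sc(Nc2ccc(Cl)cc2)nc1N(C)C` gives 3750 nM in a functional assay on COLO 201 cells (Homo sapiens) for inhibition, read by MTT assay; a lower number here means a stronger inhibitor, a higher number a weaker inhibitor. Compound 1 `CCOC(=O)/C(=C\c1ccc(B(O)O)cc1)C(=O)c1sc(Nc2ccccc2)nc1N(C)C` gives 2810 nM in this assay, and compound 2 `CCOC(=O)/C(=C\c1ccc(B(O)O)cc1)C(=O)c1sc(Nc2ccc(F)cc2)nc1-c1ccccc1` gives 5580 nM; the three numbers lie within the scatter of one another, so no order among them is established. Going by the values given here, the one measured step in this set, from compound 1 to compound 3, is a 1.3-fold higher number from compound 1 to compound 3 (0.13 log units; within the scatter). Compound 4 `CCOC(=O)/C(=C\c1ccc(B(O)O)cc1)C(=O)c1sc(Nc2ccc(OC)cc2)nc1N(C)C` differs from compound 3 by methoxy in place of chloro on an aromatic carbon. Among the compounds with values here, only that chloro step bears on this change, and it stays within the scatter; no measured pair carries a methoxy, so nothing in the data points to a shift in either direction. The expected step is therefore a 1.1-fold lower number from compound 3 to compound 4 (0.03 log units; within the scatter), not beyond the scatter. Compound 4 is estimated at 3500 nM, with a range of 1500 nM to 8000 nM.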

Compound 4, half-maximal inhibitory concentration: 5500 nM
Compound 4: middle estimate off by 1.6-fold (0.20 log units), on the low side; the measured number falls inside the stated range.
By their numbers in this assay, from the lowest: compounds 1, 3, 4 and 2 (each within the scatter of the next).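

Methoxy gives a 1.5-fold higher number from compound 3 to compound 4 (0.17 log units; within the scatter) and, against the unsubstituted ring, a 2.0-fold higher number from compound 1 to compound 4 (0.29 log units; within the scatter) in this assay. This position on the aniline ring, para to a large group, has therefore now carried hydrogen, chloro and methoxy, including a group with a hydrogen-bond acceptor, with no step beyond the scatter and no order among the three. No evidence is available to account for these numbers.

As far as these compounds go, whether an amine, a carboxylic acid or a longer alkoxy chain here would give a step beyond the scatter remains open.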